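Urea series on a shared core: step from compound 3 to compound 4

This account rests on a few compounds, and the source may have more. Where it says the series, first, only, none or still open, it means among the compounds named here.

Measured so far:
compound 1 `C[C@@H]1C[C@H](c2nc(-c3ccc4ccccc4n3)no2)CCN1C(=O)Nc1ccccc1Cl` gives 2400 nM
compound 2 `O=C(NC1CCCCC1)N1CCN(c2nc(-c3ccc4ccccc4n3)no2)CC1` gives 53 nM
compound 3 `O=C(Nc1ncccc1Cl)N1CCC(c2nc(-c3ccc4ccccc4n3)no2)CC1` gives 2800 nM

All three numbers come from a functional assay on Shh Light II cells (Mus musculus) for inhibition, read by a luciferase reporter; on this read-out lower numbers stand for stronger inhibition and higher numbers for weaker inhibition. Compound 3 gives the highest number of the three. Its nearest neighbour is compound 1, whose number lies within the scatter of that of compound 3, so no order between these two can be stated. Compound 2 is the furthest away, with a number well beyond the scatter below that of compound 3; compound 2 differs from compound 3 in more than one place, so only the two values themselves can be compared.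

Compound 4 `O=C(NC1CCOCC1)N1CCC(c2nc(-c3ccc4ccccc4n3)no2)CC1` is not yet measured in this assay. It differs from compound 3 in one place: oxan-4-yl in place of 3-chloropyridin-2-yl on an amide-type nitrogen. The amide-type nitrogen, whose other neighbour is the carbonyl carbon, keeps its hydrogen; only the group on it changes, from (3-chloropyridin-2-yl)amino to (oxan-4-yl)amino.

Among the measured compounds shown here, no step between measured compounds has been worked out for this change, so the expectation rests on the values alone. Because compound 2 gives 53 nM with a non-aromatic ring on the urea nitrogen, compound 4 is expected to move to a lower number than compound 3, a step of an 8.0-fold lower number from compound 3 to compound 4 (0.90 log units; beyond the scatter) beyond the scatter. The estimate for compound 4 is 350 nM, with a range from 70 nM to 1800 nM.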

Compound 4, half-maximal inhibitory concentration: 480 nM
Compound 4: middle estimate off by 1.4-fold (0.14 log units), on the low side; low and high end bracket the measured number.
By their numbers in this assay, from the lowest: compound 2; then compound 4; then compounds 1 and 3 (each within the scatter of the next).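

Working notes on the urea position: in this assay, the first step worked out at this position, a 5.8-fold lower number from compound 3 to compound 4 (0.77 log units; beyond the scatter), shows that the group on the amide-type nitrogen changes the reading on an otherwise unchanged core, with the amide hydrogen kept. The 3-chloropyridin-2-yl and oxan-4-yl groups have equal counts of hydrogen-bond donors and acceptors, and both are six-membered rings with one hetero atom, so the step cannot be tied to those counts; the remaining differences are an aromatic against a non-aromatic ring, the chlorine, and the ring nitrogen against the ring oxygen. No measured property of either group is available to explain the step.

Among the compounds shown here, the single step does not separate the loss of the aromatic ring from the loss of the chlorine or the gain of the ring oxygen, and an unsubstituted phenyl group or a longer alkyl chain on this nitrogen would help to tell these apart. Going by these compounds, whether a step of this size carries over to the cores of compound 1 and compound 2 also remains open.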